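Swapping the ketone-side aryl group in a pyrazole chalcone series

This account rests on a few compounds, and the source may have more. Where it says the series, first, only, none or still open, it means among the compounds named here.

Compounds measured so far:
compound 1, `COc1ccc(-c2cc(/C=C/C(=O)c3cc(OC)c(OC)c(OC)c3)[nH]n2)cc1OC`: 290 nM
compound 2, `COc1ccc(C(=O)/C=C/c2cc(-c3cc(OC)c(OC)c(OC)c3)n[nH]2)cc1`: 430 nM

In a functional assay on RPMI-8226 cells (Homo sapiens) for inhibition, read by sulforhodamine B assay, with a stated time of 48 h (on this read-out lower numbers stand for stronger inhibition of growth and higher numbers for weaker inhibition of growth), compound 2 gives 430 nM, the larger of the two numbers recorded, while compound 1 gives 290 nM. The two values sit within the usual scatter of each other, so the two compounds cannot be separated on this read-out.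

Compound 3, `COc1cc(-c2cc(/C=C/C(=O)c3ccc(F)c(F)c3)[nH]n2)cc(OC)c1OC`, has not yet been measured in this assay. Relative to compound 2 it carries a single change: 3,4-difluorophenyl in place of 4-methoxyphenyl on a carbonyl carbon. Among the measured compounds shown here, no measured pair in this set shows what such a swap on the carbonyl carbon does, so there is no basis for expecting a step beyond the scatter in either direction; a small shift toward a higher number is at most a loose guess. Compound 3 is therefore expected to give about 600 nM in this assay, within 250 nM to 1500 nM, which corresponds to an estimated step of a 1.4-fold higher number from compound 2 to compound 3 (0.14 log units; within the scatter).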

Compound 3, concentration for 50% growth inhibition: 1760 nM
The estimate for compound 3 lay 2.9-fold (0.47 log units) below the measured number, and the stated range ends below it.
By their numbers in this assay, from the lowest: compounds 1 and 2 (each within the scatter of the next); then compound 3.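

In this assay, among the compounds shown here, the first readable step at this position comes from 3,4-difluorophenyl in place of 4-methoxyphenyl on a carbonyl carbon (a 4.1-fold higher number from compound 2 to compound 3 (0.61 log units; beyond the scatter)), so the aryl group held there does affect growth inhibition. The change exchanges a group with one hydrogen-bond acceptor for one with none, and it also exchanges the oxygen-bearing substituent for two fluorines, but this single pair cannot separate those differences. Nothing available here bears on why the number rises.

As far as these compounds go, whether the higher number follows from the two fluorines entering or the methoxy group leaving remains open. Also open, from the compounds shown here alone, is how an unsubstituted phenyl, a morpholine or a carboxylic acid on the same carbonyl carbon would compare with compound 2 and compound 3.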